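Swapping the oxadiazole for a dimethylthiazole: permeability outlook

The source may hold more compounds than are shown below. What is called first, only, known or untested is meant among the compounds shown, and "the series" means these compounds.

Compound 1, `CC(C)c1noc(-c2cccc(CNc3ccc4[nH]nc(C(=O)O)c4c3)c2O)n1`, is the reference point here. Among the compounds with values here, in an ADME assay on MDCK cells (Canis lupus familiaris) for permeability, in the apical to basolateral direction (on this read-out higher numbers stand for higher permeability and lower numbers for lower permeability), compound 1 gives 3.7 10^-6 cm/s, the only full number available for this series. Compound 2, `CC(C)c1csc(-c2cccc(CN(C)c3ccc4[nH]nc(C(=O)O)c4c3)c2O)n1`, carries a thiazole and a methylated amine linker. In this assay, within the data shown here, compound 2 returns only a limit of the measurement, < 0.05 10^-6 cm/s, so the two known compounds sit apart in kind, with one reading the limit of < 0.05 10^-6 cm/s in this assay, at which 1 of the 2 values shown sits, and no single-point step connecting them.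

Compound 3, `Cc1nc(-c2cccc(CNc3ccc4[nH]nc(C(=O)O)c4c3)c2O)sc1C`, differs from compound 1 in one place: 4,5-dimethyl-1,3-thiazol-2-yl in place of 3-isopropyl-1,2,4-oxadiazol-5-yl on an aromatic carbon. Among the measured compounds shown here, with no measured step between two compounds that differ in just one place, the size of this change cannot be read off directly. The expected step from compound 1 to compound 3 is a modest decrease, a 2.1-fold lower number from compound 1 to compound 3 (0.31 log units; beyond the scatter), which may not exceed the usual scatter. Compound 3 is therefore estimated at 1.8 10^-6 cm/s, within a range from 0.3 10^-6 cm/s to 8 10^-6 cm/s.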

Compound 3, apparent permeability: 3.8 10^-6 cm/s
Estimate against measurement, compound 3: 2.1-fold (0.32 log units) below; the measured number falls inside the stated range.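

In this assay, the swap gives a 1.0-fold higher number from compound 1 to compound 3 (0.01 log units; within the scatter), so on an aromatic carbon ortho to a hydroxy group, 4,5-dimethyl-1,3-thiazol-2-yl takes the place of 3-isopropyl-1,2,4-oxadiazol-5-yl with no change beyond normal repeat variation. Within the data shown here, this is the first direct reading of a single change, and it shows that this position accepts a thiazole as well as an oxadiazole without a visible shift in this read-out. Compound 2 differs from compound 3 in more than one place and its value is only a limit, so no step to it can be read: the limit of < 0.05 10^-6 cm/s in this assay, at which 1 of the 3 values shown sits.

Going by these compounds, what a phenyl ring or a primary amide would do at this position remains open. Also open, on these data alone, is how a methyl group on the linker amine acts alone, with the rest of compound 1 kept.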